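The compounds below may be only part of what the source reports. "The series", "measured", "known", "first", "only" and "open" are said of these compounds alone.

Measured so far:
compound 1 `O[C@@H](CCc1ccccc1)C[C@@H](O)CCc1ccccc1`: 99.8 ug/mL
compound 2 `O[C@H](CCc1ccccc1)C[C@@H](O)CCc1ccccc1`: 40.5 ug/mL

In a functional assay on THP-1 cells (Homo sapiens) for antiproliferative activity, read by MTT assay, with a stated time of 48 h (a lower number here means a stronger inhibitor, a higher number a weaker inhibitor), compound 1 gives the highest of the two numbers; its nearest neighbour is compound 2, with the step of a 2.5-fold lower number from compound 1 to compound 2 (0.39 log units; beyond the scatter), which rests on (the fact that compounds 1 and 2 differ only in the configuration as drawn). Compound 3 `Oc1ccc(CC[C@H](O)C[C@@H](O)CCc2ccccc2)cc1` carries the change (hydroxy in place of hydrogen on an aromatic carbon). Among the measured compounds shown here, no measured step involves such a change; the only step known is the change of configuration between compound 1 and compound 2, which says nothing about a hydroxy added to the ring. The step from compound 1 to compound 3 is therefore expected to stay within the scatter, a 1.0-fold higher number from compound 1 to compound 3 (0.00 log units; within the scatter). Compound 3 is estimated at 100 ug/mL, between 40 ug/mL and 250 ug/mL.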

Compound 3, half-maximal inhibitory concentration: 12.8 ug/mL
For compound 3 the middle estimate is 7.8-fold (0.89 log units) above the measured one; the measured number lies below the stated range.
By their numbers in this assay, from the lowest: compound 3; then compound 2; then compound 1.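

In this assay, replacing phenyl with 4-hydroxyphenyl gives a 7.8-fold lower number from compound 1 to compound 3 (0.89 log units; beyond the scatter). This shows that the number responds to a change on the aromatic ring itself, para to a large group, and not only to the change of configuration seen earlier. Nothing known here explains why this hydroxy has that effect.

Whether the hydroxy itself is needed remains open, since only this one group is shown at this place. A methoxy, an amine or a fluorine in the same place could separate the effect of hydroxy from that of any added group.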